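Chloro to trifluoromethyl in the pyridyl carbinol series

A few compounds are considered here, and "the series" means these few. Any claim that something is new, unique, unknown or untested is made for them only; others in the source may bear on it.

Measured in a physicochemical assay for solubility, read by nephelometry, measured as kinetic solubility, at pH 6.5; on this read-out lower numbers stand for lower solubility and higher numbers for higher solubility:
- Compound 1 `N#Cc1ccc(C(O)(c2ccc(C(F)(F)F)cc2)c2cccnc2)cc1`: 6.3 ug/mL
- Compound 2 `N#Cc1ccc(C(O)(c2ccc(C(F)(F)F)cc2)c2cccnc2)c(F)c1`: 6.3 ug/mL
- Compound 3 `OC(c1ccc(Cl)cc1)(c1cccnc1)c1ccc(Cl)cc1F`: 1.6 ug/mL

Compound 3 is the lowest of the three, with compound 1 and compound 2 both higher, beyond the scatter. Compound 4 `OC(c1ccc(C(F)(F)F)cc1)(c1cccnc1)c1ccc(Cl)cc1F` has trifluoromethyl in place of chloro on an aromatic carbon, para to a large group (trifluoromethyl in place of chloro on an aromatic carbon). Among the measured compounds shown here, the only measured step, no change at the digits printed from compound 1 to compound 2 (within the scatter), is a different exchange and does not test this one. Compound 1 and compound 2 carry trifluoromethyl but also differ from compound 3 elsewhere, so their values cannot be assigned to that group. In this assay, no change beyond the scatter is therefore expected, with the estimated step being a 1.4-fold higher number from compound 3 to compound 4 (0.14 log units; within the scatter). Compound 4 is estimated at 2.2 ug/mL, with an expected range of 1 ug/mL to 5 ug/mL.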

Compound 4, solubility: < 1.6 ug/mL
Compound 4: only a limit was reported; the forecaster's own chance of this, stated with the estimate: 5%; middle value at least 1.3-fold (0.13 log units) from the limit.
By their numbers in this assay, from the lowest: compound 3; then compounds 1 and 2 (each within the scatter of the next).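

In this assay compound 4 gives < 1.6 ug/mL, which is a limit of the assay and not a number. Trifluoromethyl in place of chloro on an aromatic carbon gives a number no higher from compound 3 to compound 4 (the limit leaves the size open), and its size cannot be read because the step ends at a limit: the limit of < 1.6 ug/mL in this assay, at which 1 of the 4 values shown sits. With trifluoromethyl kept, chloro in place of cyano gives an at least 3.9-fold lower number from compound 2 to compound 4 (0.59 log units; beyond the scatter) and 4-chloro-2-fluorophenyl in place of 4-cyanophenyl gives an at least 3.9-fold lower number from compound 1 to compound 4 (0.59 log units; beyond the scatter), so trifluoromethyl alone does not go with the higher numbers.

From the compounds shown here alone, how far compound 4 lies under the limit stays open. Also open, going by these compounds, is whether an amine or a carboxylic acid at this position would give a readable, higher number.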